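Cytotoxicity notes: cyclohexyl on the nitrogen of compound 1

A few compounds are considered here, and "the series" means these few. Any claim that something is new, unique, unknown or untested is made for them only; others in the source may bear on it.

Measured values (an ADME assay on MT4 cells (Homo sapiens) for cytotoxicity, read by MTT assay, with a stated time of 96 h; on this read-out higher numbers stand for lower toxicity in this test and lower numbers for higher toxicity in this test)
- compound 1 `COc1ccc(-c2nc3cc(C(C)=O)ccc3[nH]2)c(OC)c1` gives 50000 nM
- compound 2 `COc1ccc(-c2nc3cc(C(C)=O)ccc3[nH]2)c(OC)c1OC` gives > 100000 nM
- compound 3 `COc1ccc(-c2nc3cc(/C(C)=N/NC(N)=O)ccc3[nH]2)c(OC)c1` gives 21000 nM
- compound 4 `COc1ccc(-c2nc3cc(C(C)=O)ccc3n2C2CCCCC2)c(OC)c1` is not yet measured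

Compound 1 at 50000 nM is the higher of the two actual numbers in this assay and compound 3 at 21000 nM is the other. For compound 2 the reading > 100000 nM is a limit and not a number.

The step to compound 4 is cyclohexyl in place of hydrogen on an aromatic nitrogen. Neither measured step touches that nitrogen, so both serve only as a guide to size. Changes on aromatic carbon gave an at least 2.0-fold higher number from compound 1 to compound 2 (0.30 log units; that floor lies within the scatter) and a 2.4-fold lower number from compound 1 to compound 3 (0.38 log units; beyond the scatter) in the same test. Only the second of these is a fall, and compound 2 does not follow that direction.

On the evidence of compound 3 (a 2.4-fold lower number from compound 1 to compound 3 (0.38 log units; beyond the scatter)), a modest fall is expected for compound 4, with wide uncertainty. The expected change is a 2.0-fold lower number from compound 1 to compound 4 (0.30 log units; within the scatter) in this assay and may not clear the scatter. For compound 4 the estimated value is 25000 nM with an expected range from 7000 nM to 90000 nM as the working figures.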

Compound 4, half-maximal cytotoxic concentration: 21000 nM
Compound 4: the middle estimate sits 1.2-fold (0.08 log units) above what was measured, within the range that was stated.
By their numbers in this assay, from the lowest: compounds 3 and 4 (each within the scatter of the next); then compound 1. At a limit, above all of these: compound 2.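

In this assay, among these compounds, the first change on the aromatic nitrogen gives a 2.4-fold lower number from compound 1 to compound 4 (0.38 log units; beyond the scatter) and so shows that this position, which neither earlier step touched, does move the read-out beyond the scatter. The fall is modest, and it shows that putting cyclohexyl, a six-membered non-aromatic ring of carbon only, in place of the hydrogen on this nitrogen lowers the number without a large drop in this test. The measurements shown give no cause for this fall, and nothing here separates the loss of the hydrogen from the arrival of the ring.

Among the compounds shown here, open is whether a methyl group, a longer chain such as n-butyl or a piperidine ring carrying an amine on the same nitrogen would lower the number as cyclohexyl does, so the single step cannot yet be read as a trend with size or ring type. Also open, on these data alone, is how cyclohexyl on this nitrogen behaves on the core of compound 2, whose reading of > 100000 nM is a limit of the assay and not a number.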